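Swapping Phenyl for Hydroxypyridinyl on a Shared Acid Core

The source may hold more compounds than are shown below. What is called first, only, known or untested is meant among the compounds shown, and "the series" means these compounds.

Compound 1 `O=C(O)Cc1sc(NC(=O)c2ccccc2)nc1-c1ccc(Cl)cc1` gives 870 nM in an in vitro functional assay on HEK285-7 cells for antagonist activity at prostaglandin D2 receptor 2 (Homo sapiens), read by BRET and beta-arrestin recruitment; a higher number here means a weaker inhibitor, a lower number a stronger inhibitor.
Compound 2 `O=C(O)Cc1sc(C(c2ccc(F)cc2)c2ccc(F)cc2)nc1-c1ccccc1` gives 240 nM in this assay.
Compound 3 `O=C(O)Cc1sc(C(c2ccccc2)c2ccccc2)nc1-c1ccc(C(F)(F)F)cc1` gives only a limit of this assay, > 100000 nM, as noted in the limit of > 100000 nM in this assay, at which 1 of the 3 values shown sits.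

Compound 2 stands at the lowest of the two numbers shown; compound 1 sits at a higher number, a gap beyond the usual scatter. Compound 4 `O=C(O)Cc1sc(C(c2ccc(F)cc2)c2ccc(F)cc2)nc1-c1ccnc(O)c1` keeps the rest of compound 2 and changes one group: 2-hydroxypyridin-4-yl in place of phenyl on an aromatic carbon. Among the compounds with values here, no measured pair shows this particular change, so its effect can only be estimated from compound 2 itself. The step from compound 2 to compound 4 is expected to be a 2.5-fold higher number from compound 2 to compound 4 (0.40 log units; beyond the scatter), a modest move toward a higher number, close to the edge of the scatter. Compound 4 is therefore estimated at 600 nM, between 150 nM and 2500 nM.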

Compound 4, half-maximal inhibitory concentration: 890 nM
The estimate for compound 4 lay 1.5-fold (0.17 log units) below the measured number, within the range that was stated.
By their numbers in this assay, from the lowest: compound 2; then compounds 1 and 4 (each within the scatter of the next). At a limit, above all of these: compound 3.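

Putting 2-hydroxypyridin-4-yl in place of phenyl on this aromatic carbon, next to the ring nitrogen, gives a 3.7-fold higher number from compound 2 to compound 4 (0.57 log units; beyond the scatter) in this assay. This position therefore accepts a ring carrying nitrogen and oxygen at a modest cost, and compound 4 remains a measurable inhibitor. Nothing measured here bears on why the number rose.

On these data alone, what remains open is how the ring nitrogen and the hydroxyl group each contribute. Plain pyridin-4-yl and 4-hydroxyphenyl would be needed to separate them.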